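Series notes: heptyl in place of the hydroxyphenyl arm

A few compounds are considered here, and "the series" means these few. Any claim that something is new, unique, unknown or untested is made for them only; others in the source may bear on it.

Going by the values given here, compound 1 `Oc1ccc(C(c2c[nH]c3ccc(Br)cc23)c2c[nH]c3ccc(Br)cc23)cc1` gives 3500 nM in a functional assay on MCF7 cells (Homo sapiens) for inhibition, read by MTT assay, with a stated time of 48 h (on this read-out higher numbers stand for weaker inhibition and lower numbers for stronger inhibition), and stands second highest of the three numbers measured so far. Compound 3 `O=[N+]([O-])c1ccc(C(c2c[nH]c3ccc(Br)cc23)c2c[nH]c3ccc(Br)cc23)cc1` gives 3100 nM, and that pair shows a 1.1-fold lower number from compound 1 to compound 3 (0.05 log units; within the scatter). Compound 2 `COc1ccc(C(c2c[nH]c3ccc(Br)cc23)c2c[nH]c3ccc(Br)cc23)cc1OC` gives 7800 nM, a change of a 2.2-fold higher number from compound 1 to compound 2 (0.35 log units; beyond the scatter). Compound 4 `CCCCCCCC(c1c[nH]c2ccc(Br)cc12)c1c[nH]c2ccc(Br)cc12` carries heptyl in place of 4-hydroxyphenyl on a saturated chain carbon bound to two aromatic carbons. Among the compounds with values here, no measured step exchanges the aromatic group for a chain; both steps leaving compound 1 keep an aromatic ring on that carbon, and of these a 2.2-fold higher number from compound 1 to compound 2 (0.35 log units; beyond the scatter) is modest while a 1.1-fold lower number from compound 1 to compound 3 (0.05 log units; within the scatter) stays within the scatter. The expectation for compound 4 is therefore a modest step toward a higher number at most, a 1.6-fold higher number from compound 1 to compound 4 (0.20 log units; within the scatter). Compound 4 is estimated at 5500 nM, with a range from 2000 nM to 16000 nM.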

Compound 4, half-maximal inhibitory concentration: 5500 nM
Compound 4: the middle estimate sits on the measured number at the digits printed; the range from low to high includes it.
By their numbers in this assay, from the lowest: compounds 3, 1, 4 and 2 (each within the scatter of the next, the first and the last beyond it).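

In this assay the saturated chain carbon bound to two aromatic carbons keeps its level of inhibition without any aromatic ring: heptyl, which has no ring and no hydrogen-bond donor or acceptor, gives a 1.6-fold higher number from compound 1 to compound 4 (0.20 log units; within the scatter) and a 1.8-fold higher number from compound 3 to compound 4 (0.25 log units; within the scatter) and a 1.4-fold lower number from compound 2 to compound 4 (0.15 log units; within the scatter) with all three steps within the scatter. Neither the ring nor the hydroxy of 4-hydroxyphenyl is therefore needed at this place. Nothing measured on these compounds points to a cause for this.

The compounds shown leave open whether a shorter chain such as propyl or a longer chain such as dodecyl holds the same level. They also leave open whether heptyl tolerates an amine or a carboxylic acid at its end.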